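The compounds below may be only part of what the source reports. "The series", "measured", "known", "first", "only" and "open" are said of these compounds alone.

Compound 1 `Cc1ccc(-c2ccc(F)cc2)n1-c1ccc(-c2nc3ccccc3s2)cc1` gives 11800 nM in a functional assay on MDA-MB-231 cells (Homo sapiens) for cytotoxicity, read by MTT assay, with a stated time of 72 h; on this read-out higher numbers stand for weaker inhibition and lower numbers for stronger inhibition. Its only companion, compound 2 `Cc1ccc(-c2ccc([N+](=O)[O-])cc2)n1-c1ccc(-c2nc3ccccc3s2)cc1`, gives 12100 nM; the two values sit within the scatter of each other, as the step of a 1.0-fold higher number from compound 1 to compound 2 (0.01 log units; within the scatter) shows. Compound 3 `COc1ccc2nc(-c3ccc(-n4c(C)ccc4-c4ccc(F)cc4)cc3)sc2c1` differs from compound 1 by methoxy in place of hydrogen on an aromatic carbon. Going by the values given here, no measured step touches that position, and the single step from compound 1 to compound 2 changed a different group at a different place without moving the number beyond the scatter. On that basis, the step of a 1.1-fold lower number from compound 1 to compound 3 (0.03 log units; within the scatter) is expected to stay within the scatter. Compound 3 is therefore estimated at 11000 nM, within 5000 nM to 25000 nM.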

Compound 3, half-maximal inhibitory concentration: 13800 nM
Compound 3: middle estimate off by 1.3-fold (0.10 log units), on the low side; the measured number falls inside the stated range.
By their numbers in this assay, from the lowest: compounds 1, 2 and 3 (each within the scatter of the next).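

Putting methoxy in place of hydrogen on this aromatic carbon of the fused ring system gives a 1.2-fold higher number from compound 1 to compound 3 (0.07 log units; within the scatter) in this assay. This position therefore accepts methoxy with no change that can be told from the scatter, at least with the fluoro group of compound 1 in place. No outside measurement bears on this result, so no cause can be given.

The compounds shown leave open whether an amine, a carboxylic acid or a longer chain such as butoxy on this carbon would also leave the number unchanged. They also leave open whether methoxy behaves alike with the nitro group of compound 2.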